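This account rests on a few compounds, and the source may have more. Where it says the series, first, only, none or still open, it means among the compounds named here.

The measured compounds are:
compound 1, `Cc1cc(C)cc(S(=O)(=O)c2cnc3ccc(F)cc3c2N2CCC(C)CC2)c1`, 83%
compound 2, `CC1CCN(c2c(S(=O)(=O)c3cc(Cl)cc(Cl)c3)cnc3cc(Cl)ccc23)CC1`, 93%
compound 3, `Cc1ccc2ncc(S(=O)(=O)c3ccc(C)c(Cl)c3)c(N3CCC(C)CC3)c2c1`, 91%

In an assay on isolated protein for displacement of a labelled ligand from metabotropic glutamate receptor 5 (Homo sapiens), with a stated time of 60 min, tested at 1 uM (a lower number here means less inhibition, a higher number more inhibition at the concentration tested (going by the name of the read-out)), compound 1 gives 83%, the lowest of the three numbers, yet its gaps to compound 3 and to compound 2 both lie within the usual scatter of this kind of measurement, so the three compounds cannot be separated on these numbers. Compound 4, `CC1CCN(c2c(S(=O)(=O)c3cccc(Cl)c3)cnc3ccc(F)cc23)CC1`, has not been measured in this assay. It differs from compound 1 in one place: 3-chlorophenyl in place of 3,5-dimethylphenyl on a sulfonyl sulfur. Among the compounds with values here, no pair of measured compounds differs in a single place, so no measured step shows what such a change does; the only guide is that all three measured compounds, each carrying a different group on the sulfonyl sulfur, give numbers close to one another. The step of a number 2 percentage points higher from compound 1 to compound 4 (within the scatter) is therefore expected to be small, not beyond the scatter. For compound 4 the expected value in this assay is 85%, within a range from 70% to 96%.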

Compound 4, a percentage reported as inhibition, at one concentration (the size of the read-out at that concentration, not a potency): 92%
Compound 4: middle estimate off by 7 percentage points, on the low side; measured number inside the range.
By their numbers in this assay, from the lowest: compounds 1, 3, 4 and 2 (each within the scatter of the next).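

In this assay, the exchange of 3,5-dimethylphenyl for 3-chlorophenyl on a sulfonyl sulfur gives the first step read with the rest of the molecule unchanged: a number 9 percentage points higher from compound 1 to compound 4 (within the scatter). The earlier compounds shown here differed in more than one place, whereas this pair shows directly that this single change cannot be told apart from no change in this read-out, so both groups are compatible with a high number here. No measurement shown offers an explanation for this step.

The compounds shown carry only phenyl rings with chlorine or methyl on the sulfonyl sulfur, leaving open whether a carboxylic acid or an amine on that ring, or a longer chain in its place, would keep the number. From the compounds shown here alone, since the read-out is a percentage at one concentration, how compound 1 and compound 4 compare in potency also remains open.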